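Aryl Variation in a Coumarin-Linked Dienone Series

The compounds below may be only part of what the source reports. "The series", "measured", "known", "first", "only" and "open" are said of these compounds alone.

The measured compounds and their values:
compound 1 `COc1cc(/C=C/C(=O)/C=C/c2cccc3ccccc23)ccc1OCc1cn(CCOc2cc(=O)oc3ccccc23)nn1` — 9950 nM
compound 2 `COc1cc(/C=C/C(=O)/C=C/c2cccs2)ccc1OCc1cn(CCOc2cc(=O)oc3ccccc23)nn1` — 11400 nM
compound 3 `COc1cccc(/C=C/C(=O)/C=C/c2ccc(OCc3cn(CCOc4cc(=O)oc5ccccc45)nn3)c(OC)c2)c1` — 11900 nM

All three compounds share the same core and differ only in the aryl group on a double-bonded chain carbon bound to a double-bonded chain carbon. In a functional assay on COLO 205 cells (Homo sapiens) for cytotoxicity, read by sulforhodamine B assay, with a stated time of 48 h (a higher number here means a weaker inhibitor, a lower number a stronger inhibitor), compound 3 gives 11900 nM, the highest of the three numbers, yet it stands within the scatter of both neighbours: a 1.0-fold higher number from compound 2 to compound 3 (0.02 log units; within the scatter) and a 1.2-fold higher number from compound 1 to compound 3 (0.08 log units; within the scatter). The remaining step, a 1.1-fold higher number from compound 1 to compound 2 (0.06 log units; within the scatter), is likewise within the scatter. Taken together, swapping the aryl group among these three produced no change beyond the usual repeat-to-repeat variation.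

Compound 4 `COc1cc(/C=C/C(=O)/C=C/c2cc(OC)c(OC)c(OC)c2)ccc1OCc1cn(CCOc2cc(=O)oc3ccccc23)nn1` is not yet measured. It differs from compound 3 as follows: 3,4,5-trimethoxyphenyl in place of 3-methoxyphenyl on a double-bonded chain carbon bound to a double-bonded chain carbon. Within the data shown here, no measured step involves a change in the number of methoxy groups on the aryl ring, so the three aryl swaps are the only guide, and each of them was within the scatter. On that basis compound 4 is expected to behave much like compound 3, with an estimated step of a 1.1-fold lower number from compound 3 to compound 4 (0.03 log units; within the scatter) in this assay. The estimate for compound 4 is 11000 nM, with a range from 5000 nM to 25000 nM.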

Compound 4, half-maximal inhibitory concentration: 4680 nM
Beside the measured number, compound 4's estimate is 2.4-fold (0.37 log units) above it; the measured number lies below the stated range.
By their numbers in this assay, from the lowest: compound 4; then compounds 1, 2 and 3 (each within the scatter of the next).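

Among these compounds, at this position, on a double-bonded chain carbon bound to a double-bonded chain carbon, the identity of the aryl group does matter in this assay after all: 3,4,5-trimethoxyphenyl in place of 3-methoxyphenyl gives a 2.5-fold lower number from compound 3 to compound 4 (0.41 log units; beyond the scatter) and is the first change to clear the scatter. The same group also stands apart from the other two aryl groups, with a 2.4-fold lower number from compound 2 to compound 4 (0.39 log units; beyond the scatter) when it replaces thiophen-2-yl and a 2.1-fold lower number from compound 1 to compound 4 (0.33 log units; beyond the scatter) when it replaces naphthalen-1-yl, so compound 4 is the most potent of the four, though each step is modest. The position therefore responds to one particular group, while the other three aryl groups remain level with one another, which means that the apparent flatness of the earlier swaps did not hold across the wider set.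

Nothing available here bears on why this group lowers the number. From the compounds shown here alone, it remains open whether a 4-methoxyphenyl or a 3,4-dimethoxyphenyl group would carry part of this step, and whether a 3,4,5-trihydroxyphenyl group or an aminophenyl group would keep it.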